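This account rests on a few compounds, and the source may have more. Where it says the series, first, only, none or still open, it means among the compounds named here.

The measured compounds:
compound 1, `CNc1nc(Nc2ccc(C#N)cc2)nc(Oc2ccc(Cl)c3ccccc23)n1`, 197000 nM
compound 2, `CCNc1nc(Nc2ccc(C#N)cc2)nc(Oc2ccc(Cl)c3ccccc23)n1`, 208000 nM
compound 3, `CCNc1nc(Nc2ccc(C#N)cc2)nc(Oc2ccc3cc(Br)ccc3c2Br)n1`, 74400 nM

All three were tested in an ADME assay on MT4 cells (Homo sapiens) for cytotoxicity, read by MTT assay, with a stated time of 4 days; a lower number here means that less compound is tolerated, a higher number that more compound is tolerated. Compound 2 differs from compound 1 by methyl in place of hydrogen on a saturated chain carbon bound to a nitrogen on an aromatic ring, and that change made a 1.1-fold higher number from compound 1 to compound 2 (0.02 log units; within the scatter). Compound 3 shares only part of its structure with compound 1; the difference between the two cores is not broken down here. In this assay compound 3 gives a lower number than compound 1 and compound 2, in both cases beyond the scatter.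

Compound 4, `CCCNc1nc(Nc2ccc(C#N)cc2)nc(Oc2ccc3cc(Br)ccc3c2Br)n1`, has not yet been measured. It differs from compound 3 by methyl in place of hydrogen on a saturated chain carbon, two bonds along the chain from a nitrogen on an aromatic ring. Within the data shown here, this is the same kind of change as the one from compound 1 to compound 2, though the place is not the same: there the methyl entered on a saturated chain carbon bound to a nitrogen on an aromatic ring, here on a saturated chain carbon two bonds along the chain from such a nitrogen. Because the earlier change made a 1.1-fold higher number from compound 1 to compound 2 (0.02 log units; within the scatter), a similarly small step is expected, a 1.1-fold lower number from compound 3 to compound 4 (0.03 log units; within the scatter). Compound 4 is therefore expected to give about 70000 nM in this assay, most likely between 35000 nM and 140000 nM.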

Compound 4, half-maximal cytotoxic concentration: 134000 nM
Beside the measured number, compound 4's estimate is 1.9-fold (0.28 log units) below it; low and high end bracket the measured number.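

In this assay, the methyl that turns ethylamino into propylamino gave a 1.8-fold higher number from compound 3 to compound 4 (0.26 log units; within the scatter) and cannot be told apart from the earlier step on the other core: the same change on two cores in this assay, a 1.1-fold higher number (0.02 log units; within the scatter) from compound 1 to compound 2 and a 1.8-fold higher number (0.26 log units; within the scatter) from compound 3 to compound 4, 1.7-fold (0.23 log units) apart, within the scatter of two such steps. So on these two cores, the change carried over with both steps staying within the scatter, which fits a small effect of this added methyl on the number in this assay. It does not show that the step would hold on a further core, and the two steps are not strictly alike, since one methyl entered on a saturated chain carbon bound to a nitrogen on an aromatic ring and the other two bonds along the chain from such a nitrogen.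

The compounds shown leave open whether a longer chain, a branched chain or a chain ending in an amine or a carboxylic acid would also stay within the scatter. They also leave open how this change reads on other cores and in any measurement beyond this assay.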